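Neopentyl for Cyclopropyl on the Shared Core

The source may hold more compounds than are shown below. What is called first, only, known or untested is meant among the compounds shown, and "the series" means these compounds.

Compound 1 `CC(C)(C)CCn1nc(C2CC2)c(O)c(C2=NS(=O)(=O)c3cc(NS(C)(=O)=O)ccc3N2)c1=O` is characterised in a physicochemical assay for solubility, at pH 7.4; a higher number here means a more soluble compound, a lower number a less soluble compound. In this assay compound 1 gives > 50000 nM, which is a limit of the assay and not a number. Two related compounds sit in the same series. Compound 2 `CN(c1ccc2c(c1)S(=O)(=O)N=C(c1c(O)c(-c3cccs3)nn(CCC(C)(C)C)c1=O)N2)S(C)(=O)=O` gives > 100000 nM, again a limit rather than a number. Compound 3 `CC(C)CCn1nc(-c2cccs2)c(O)c(C2=NS(=O)(=O)c3cc(N(C)S(C)(=O)=O)ccc3N2)c1=O` gives > 100000 nM, also a limit. Going by the values given here, the only single-point step among them, a step that the two limits leave unreadable from compound 2 to compound 3, concerns a different change and has no readable size, so none of the measured steps bears directly on the change considered here. Compound 1 stands at the limit of > 50000 nM in this assay, at which 1 of the 3 values shown sits, while the other two stand at the limit of > 100000 nM in this assay, at which 2 of the 3 values shown sit.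

Compound 4 `CC(C)(C)CCn1nc(CC(C)(C)C)c(O)c(C2=NS(=O)(=O)c3cc(NS(C)(=O)=O)ccc3N2)c1=O` differs from compound 1 by neopentyl in place of cyclopropyl on an aromatic carbon. With no readable step to draw on, the expected outcome rests on the three values alone, all of which are limits. The step from compound 1 to compound 4 is therefore expected to be an at least 1.2-fold lower number from compound 1 to compound 4 (0.09 log units; that floor lies within the scatter), and compound 4 is estimated at 40000 nM, within a range from 8000 nM to 100000 nM.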

Compound 4, solubility: > 100000 nM
Compound 4: only a limit was reported; the forecaster's own chance of this, stated with the estimate: 40%; at least 2.5-fold (0.39 log units) between middle value and limit.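

In this assay compound 1 and compound 4 both give limits and not numbers, so no size can be read for neopentyl in place of cyclopropyl on an aromatic carbon. The compounds shown leave open whether that change moves the solubility read-out at all, and in which direction.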